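This account rests on a few compounds, and the source may have more. Where it says the series, first, only, none or still open, it means among the compounds named here.

Compound 1, `CC(O)(C(=O)Nc1ccc(S(=O)(=O)c2ccc(C#N)cc2)cc1)C(F)(F)F`: in a functional assay (Cavia porcellus) with sulfonylurea receptors; K-ATP channels (Homo sapiens) as the target (on this read-out lower numbers stand for stronger inhibition and higher numbers for weaker inhibition), compound 1 gives > 30000 nM, which is a limit of the assay and not a number.
Compound 2, `COc1cccc(S(=O)(=O)c2ccc(NC(=O)C(C)(O)C(F)(F)F)cc2)c1`: in this assay compound 2 gives 16000 nM.
Compound 3, `COc1ccc(S(=O)(=O)c2ccc(NC(=O)C(C)(O)C(F)(F)F)cc2)cc1`: in this assay compound 3 gives > 30000 nM, a limit of the assay rather than a number.

Compound 3 thus stands only at a limit, and (the limit of > 30000 nM in this assay, at which 2 of the 3 values shown sit). Among the measured compounds shown here, the single number, that of compound 2, points to weak inhibition, and the step of an at least 1.8-fold higher number from compound 2 to compound 3 (0.27 log units; that floor lies within the scatter) carries compound 3 back to the limit. The step that the two limits leave unreadable from compound 1 to compound 3 cannot be sized.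

Compound 4, `CC(O)(C(=O)Nc1ccc(S(=O)(=O)c2ccc(Br)cc2)cc1)C(F)(F)F`, has not yet been measured in this assay. The change from compound 3 is bromo in place of methoxy on an aromatic carbon. For the measured compounds named here, no measured step puts a bromo in place of another group; the steps that come closest are an at least 1.8-fold lower number from compound 1 to compound 2 (0.27 log units; that floor lies within the scatter) and an at least 1.8-fold higher number from compound 2 to compound 3 (0.27 log units; that floor lies within the scatter), both small and at the edge of the scatter, plus the unreadable a step that the two limits leave unreadable from compound 1 to compound 3. Every change so far on that outer ring has left the compounds weak, so no step beyond the scatter is expected from compound 3 to compound 4. The expected step is a number no higher from compound 3 to compound 4 (the limit leaves the size open). Compound 4 is estimated at 30000 nM, with a range from 8000 nM to 100000 nM, and a real chance that only a limit is reported.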

Compound 4, half-maximal inhibitory concentration: > 30000 nM
Compound 4: only a limit was reported; the forecaster's own chance of this, stated with the estimate: 60%; the middle value sits exactly at the limit.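

Bromo now joins cyano and methoxy as a third group para to a large group, and in this assay compound 4, like compound 1 and compound 3, stops at a limit of the assay rather than at a number. The steps to compound 4 from compound 1 and from compound 3 cannot be read, as both ends of each are limits. The one readable step is an at least 1.8-fold higher number from compound 2 to compound 4 (0.27 log units; that floor lies within the scatter), so it does not separate these two compounds, and the only actual number still belongs to compound 2, the one exception to a series that otherwise ends at the limit: the limit of > 30000 nM in this assay, at which 3 of the 4 values shown sit.

As far as these compounds go, it remains open whether any other group at this place, such as an amine, a carboxylic acid or a longer chain, would give a number in this assay that stands clearly lower than the values seen so far. From the compounds shown here alone, the order of compound 1, compound 3 and compound 4 among themselves also stays unknown, and so does how much inhibition, if any, each of them would show at higher concentrations.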